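The source may hold more compounds than are shown below. What is called first, only, known or untested is meant among the compounds shown, and "the series" means these compounds.

Of the compounds shown here, two sharing one core have been measured so far in a functional assay on MCF7 cells (Homo sapiens) for antiproliferative activity, read by MTT assay, with a stated time of 48 h; on this read-out lower numbers stand for stronger inhibition and higher numbers for weaker inhibition. Compound 1 `O=[N+]([O-])c1cc(C(F)(F)F)cc([N+](=O)[O-])c1Oc1ccc(Br)cc1/C=N\OCc1ccccc1` gives 1150 nM, and compound 2 `O=[N+]([O-])c1cc(C(F)(F)F)cc([N+](=O)[O-])c1Oc1ccc(Br)cc1/C=N/OCc1ccccc1Cl` gives 2840 nM, the higher of the two numbers and so the weaker inhibition. The next structure, compound 3 `O=[N+]([O-])c1cc(C(F)(F)F)cc([N+](=O)[O-])c1Oc1ccc(Br)cc1/C=N\OCc1ccc(Cl)cc1Cl`, changes one part of compound 2, and the change is this: a group of 12 heavy atoms (8 carbon, 1 nitrogen, 1 oxygen, 2 chlorine; one six-membered aromatic ring of carbon only) in place of a group of 11 heavy atoms (8 carbon, 1 nitrogen, 1 oxygen, 1 chlorine; one six-membered aromatic ring of carbon only), on an aromatic carbon. The swap takes place on an aromatic carbon, ortho to a large group and meta to a bromo group. Among the compounds with values here, one measured step bears on it, since that swap also brought in a group holding chlorine: a 2.5-fold higher number from compound 1 to compound 2 (0.39 log units; beyond the scatter). This step is modest, and one step is a thin guide to a second. No step beyond the scatter is therefore expected in this assay, and no firm direction can be given. The expected change is a 1.1-fold lower number from compound 2 to compound 3 (0.06 log units; within the scatter). Compound 3 is estimated at about 2500 nM, with an expected range from 850 nM to 7000 nM.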

Compound 3, half-maximal inhibitory concentration: 1340 nM
Beside the measured number, compound 3's estimate is 1.9-fold (0.27 log units) above it; measured number inside the range.
By their numbers in this assay, from the lowest: compounds 1 and 3 (each within the scatter of the next); then compound 2.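

In this assay the step of a 2.1-fold lower number from compound 2 to compound 3 (0.33 log units; beyond the scatter) runs opposite to the earlier step of a 2.5-fold higher number from compound 1 to compound 2 (0.39 log units; beyond the scatter), so among these three compounds, more chlorine on this ring does not push the number in one direction. The comparison with the unsubstituted ring gives a 1.2-fold higher number from compound 1 to compound 3 (0.07 log units; within the scatter), which means that 2,4-dichlorophenyl and phenyl cannot be told apart at this position, while compound 2 stands apart from both as the weaker inhibitor. The change from compound 2 to compound 3 is also more than one added chlorine: the double bond outside the rings is drawn with the opposite geometry in compound 2, so the two structural differences cannot be separated within this step.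

No measurement at hand accounts for these shifts. From the compounds shown here alone, it remains open whether the chlorine-bearing group of compound 2, with its double bond drawn as in compound 1, would behave like compound 1, and how a methoxy group or an amine on this ring would compare with chlorine.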